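The compounds below may be only part of what the source reports. "The series", "measured", "known", "first", "only" and "open" are said of these compounds alone.

In a functional assay on OVCAR-8 cells (Homo sapiens) for antiproliferative activity (on this read-out lower numbers stand for stronger inhibition and higher numbers for weaker inhibition), compound 1 `Cn1ncc(Cl)c1-c1cc(C(=O)N[C@@H]2CN[C@H](CC(N)=O)C[C@H]2c2ccc(Cl)c(Cl)c2)oc1Cl` gives 1000 nM. Among the compounds with values here, only one other compound has been measured alongside it: compound 2 `Cn1ncc(Cl)c1-c1cc(C(=O)N[C@H]2CNCC[C@@H]2c2ccc(C(F)(F)F)cc2)oc1Cl` gives 900 nM in this assay. Compound 1 thus stands at the top of these two numbers, but the gap to compound 2 lies within the usual scatter of repeated measurements, so the two cannot be told apart on this evidence.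

Compound 3 `Cn1ncc(Cl)c1-c1cc(C(=O)N[C@@H]2CN[C@H](CC(=O)NCCO)C[C@H]2c2ccc(Cl)c(Cl)c2)oc1Cl` has not yet been measured. It differs from compound 1 in one place: 2-hydroxyethyl in place of hydrogen on an amide-type nitrogen. Within the data shown here, no step between two measured compounds is available to show what a change of this kind does in this assay, and compound 2 differs from compound 1 in several places at once, so it offers no guide.

With nothing to point in either direction, the step from compound 1 to compound 3 is expected to be no change at the digits printed from compound 1 to compound 3 (within the scatter), that is, none beyond the scatter. Compound 3 is therefore estimated at 1000 nM, with a range from 400 nM to 2500 nM.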

Compound 3, half-maximal inhibitory concentration: 1450 nM
Beside the measured number, compound 3's estimate is 1.5-fold (0.16 log units) below it; measured number inside the range.
By their numbers in this assay, from the lowest: compounds 2, 1 and 3 (each within the scatter of the next).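

In this assay, there is a 1.5-fold higher number from compound 1 to compound 3 (0.16 log units; within the scatter) when 2-hydroxyethyl takes the place of hydrogen on the amide-type nitrogen. Within the data shown here, this gives the first direct reading at this position: the amide hydrogen can be exchanged for a group of 3 heavy atoms, with no ring and no net charge, without a difference that stands out from ordinary repeat variation. No supporting information bears on this result.

From the compounds shown here alone, whether the same holds for other groups on this nitrogen remains open, such as a longer chain ending in an amine or a carboxylic acid. Also open is what the carbamoylmethyl group contributes as a whole, as no compound shown differs from compound 1 in that group alone.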